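The compounds below may be only part of what the source reports. "The series", "measured", "known", "first", "only" and "open" are said of these compounds alone.

Compound 1 `Nc1scc(CN2CCN(c3cc(Cl)cc(Cl)c3)CC2)c1C(=O)c1ccc(Cl)cc1` gives -22% in a functional assay on CHO cells with adenosine receptor A1 (Homo sapiens) as the target, read by cAMP accumulation and immunoassay, with a stated time of 6 min, tested at 0.1 uM; a higher number here means a weaker effect of the compound at the concentration tested, a lower number a stronger effect.
Compound 2 `Nc1scc(CN2CCN(c3cccc(C(F)(F)F)c3)CC2)c1C(=O)c1ccc(Cl)cc1` gives -30% in this assay.

Two compounds share one core and differ only in the aryl group on an amine nitrogen in a ring. Compound 2 and compound 1 lie within the usual scatter of each other, as the step of a number 8 percentage points lower from compound 1 to compound 2 (within the scatter) shows, so swapping one aryl group for another at this position left no trace beyond the noise of repeated measurements.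

Compound 3 `Nc1scc(CN2CCN(c3ccc(F)c(F)c3)CC2)c1C(=O)c1ccc(Cl)cc1` has not yet been measured. It carries the change (3,4-difluorophenyl in place of 3-(trifluoromethyl)phenyl on an amine nitrogen in a ring). Going by the values given here, this is the only kind of step with a measured precedent here: the single comparable step a number 8 percentage points lower from compound 1 to compound 2 (within the scatter) stayed inside the scatter. On that basis a step of a number 3 percentage points higher from compound 2 to compound 3 (within the scatter) is expected, meaning no change beyond the scatter. Compound 3 is therefore estimated to give -27%, with a likely range from -45% to -8%.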

Compound 3, a percentage reported as activity, at one concentration (the size of the read-out at that concentration, not a potency): -34%
The estimate for compound 3 lay 7 percentage points above the measured number; measured number inside the range.
By their numbers in this assay, from the lowest: compounds 3, 2 and 1 (each within the scatter of the next, the first and the last beyond it).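

In this assay, the swap of 3,5-dichlorophenyl for 3,4-difluorophenyl gives a number 12 percentage points lower from compound 1 to compound 3 (beyond the scatter), the first sign that the aryl group at this position can shift the read-out, though only slightly. By contrast, the swap of 3-(trifluoromethyl)phenyl for 3,4-difluorophenyl gives a number 4 percentage points lower from compound 2 to compound 3 (within the scatter), so these two groups cannot be told apart here. With compound 2 also within the scatter of compound 1, only the outer pair of this series separates, and no single aryl group stands apart from both others.

No measurement here accounts for the difference between compound 1 and compound 3. Going by these compounds, it also remains open whether the read-out at this position would hold with an aryl group carrying a methoxy group, an amine or a carboxylic acid.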